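Sulfonate series: chloro on the styryl ring of compound 2

The compounds below may be only part of what the source reports. "The series", "measured", "known", "first", "only" and "open" are said of these compounds alone.

Measured so far:
compound 1 `COc1ccccc1NS(=O)(=O)/C=C/c1ccccc1Cl` – 6350 nM
compound 2 `COc1ccc(OS(=O)(=O)/C=C/c2ccccc2)cc1` – 1480 nM
compound 3 `COc1cccc(OS(=O)(=O)/C=C/c2ccccc2Cl)c1` – 165 nM

In an assay on U2OS cells for activation of nuclear factor erythroid 2-related factor 2 (Homo sapiens), read by chemiluminescence, with a stated time of 6 h (a lower number here means that less compound is needed, a higher number that more compound is needed for the effect), compound 2 gives the second highest of the three numbers, with compound 1 giving 6350 nM above it and compound 3 giving 165 nM below it; both gaps lie beyond the scatter. For the measured compounds named here, no pair among the three differs in one place, so no single step is available from the numbers.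

Compound 4 `COc1ccc(OS(=O)(=O)/C=C/c2ccccc2Cl)cc1` is the one-place change from compound 2: chloro in place of hydrogen on an aromatic carbon, placed on an aromatic carbon of a six-membered aromatic ring of carbon only, ortho to a large group. Of the measured compounds, compound 3 also carries this chloro and gives 165 nM, the lowest number in this assay, while compound 1, which carries it on a different core, gives 6350 nM. For compound 4 the step of a 3.7-fold lower number from compound 2 to compound 4 (0.57 log units; beyond the scatter) in this assay is expected to point toward a lower number, beyond the scatter. Compound 4 is accordingly estimated at 400 nM, within 120 nM to 1500 nM.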

Compound 4, half-maximal effective concentration: 237 nM
For compound 4 the middle estimate is 1.7-fold (0.23 log units) above the measured one; low and high end bracket the measured number.
By their numbers in this assay, from the lowest: compounds 3 and 4 (each within the scatter of the next); then compound 2; then compound 1.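

For the compounds shown here, the chloro-for-hydrogen change now has a direct reading in this assay as a 6.2-fold lower number from compound 2 to compound 4 (0.80 log units; beyond the scatter) and is the first single-place step, with phenyl to 2-chlorophenyl alone accounting for a change beyond the scatter. Compound 3 and compound 4, both chloro sulfonates that differ only in where the methoxy group sits, lie within the scatter of each other, so this read-out does not separate those two placements. No measurement accompanies the step that could account for its size.

Going by these compounds, whether the step is particular to chloro stays open, as a fluoro, a methyl, an amine or a carboxylic acid at the same place would show. How much of the gap to compound 1 belongs to the sulfonamide link alone cannot be read, since compound 1 differs from each sulfonate in more than one place.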